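Compound 4 Carries a Fluorine That Compound 2 Lacks

A few compounds are considered here, and "the series" means these few. Any claim that something is new, unique, unknown or untested is made for them only; others in the source may bear on it.

Three compounds have been measured in a functional assay on cells (Panel NCI-60 (60 carcinoma cell lines), Homo sapiens); a lower number here means that less compound is tolerated, a higher number that more compound is tolerated:
compound 2 `O=C1C=CC(O)(c2cc3ccccc3n2S(=O)(=O)c2ccccc2)C=C1`, 2950 nM;
compound 1 `CC(C)c1cc(C(C)C)c(S(=O)(=O)n2c(C3(O)C=CC(=O)C=C3)cc3ccccc32)c(C(C)C)c1`, 11200 nM;
compound 3 `O=C1C=CC(O)(c2cc3ccccc3[nH]2)C=C1`, 24000 nM.

Among these three, compound 2 stands lowest in this assay. The nearest number belongs to compound 1, which lies beyond the scatter, and the furthest to compound 3, also beyond the scatter. Compound 2 therefore tolerates the least compound of the three. Within the data shown here, no pair of these measured compounds differs in a single place, so none of their gaps can be read as a step of its own; the numbers stand side by side only.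

Compound 4 `O=C1C=CC(O)(c2cc3ccccc3n2S(=O)(=O)c2ccc(F)cc2)C=C1` has not yet been measured. It differs from compound 2 in one place: fluoro in place of hydrogen on an aromatic carbon. Taken one bond further out, the change reads phenyl to 4-fluorophenyl. Among the measured compounds shown here, with no measured step of this kind among the compounds above, the account expects the step from compound 2 to compound 4 to stay within the scatter, in either direction, and estimates it as a 1.1-fold lower number from compound 2 to compound 4 (0.04 log units; within the scatter). On that basis compound 4 is expected to give about 2700 nM in this assay, with a likely range from 1200 nM to 6500 nM.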

Compound 4, concentration lethal to 50% of the cells: 7760 nM
Beside the measured number, compound 4's estimate is 2.9-fold (0.46 log units) below it, outside the stated range (above it).
By their numbers in this assay, from the lowest: compound 2; then compounds 4 and 1 (each within the scatter of the next); then compound 3.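

In this assay, among these compounds, the change from phenyl to 4-fluorophenyl gives the first step that can be read on its own: a 2.6-fold higher number from compound 2 to compound 4 (0.42 log units; beyond the scatter) is modest, but it lies beyond the scatter. It shows that this aromatic carbon, para to a large group, is not indifferent to what it carries, since a single fluoro in place of hydrogen moves the number upward, so that more compound is tolerated. Nothing shown here bears on why this one atom moves the number, so the step stands as an observation only.

From the compounds shown here alone, the step rests on one pair of compounds, so it remains open whether chloro, methyl or methoxy at the same carbon would move the number as fluoro does, or whether an amine or a carboxylic acid there would move it the other way. Going by these compounds, it is also open whether fluoro on another carbon of this ring would give a step of similar size in this assay or leave the number within the scatter.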